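This account rests on a few compounds, and the source may have more. Where it says the series, first, only, none or still open, it means among the compounds named here.

Compound 1 `OC(c1ccc(Cl)cc1)(c1cccnc1)c1cccs1` in an ADME assay on L6 cells (Rattus norvegicus) for cytotoxicity, read by resazurin assay, with a stated time of 72 h (a lower number here means a stronger inhibitor, a higher number a weaker inhibitor), gives 67700 nM. Compound 2 `OC(c1cccnc1)(c1cccs1)c1ccc(Cl)cc1F` in this assay gives > 100000 nM, which is a limit of the assay rather than a number. The change between them, (fluoro in place of hydrogen on an aromatic carbon), made a step of an at least 1.4-fold higher number from compound 1 to compound 2 (0.16 log units; that floor lies within the scatter). Compound 3 `CC(C)Oc1ncc(C(O)(c2ccc(Cl)cc2)c2cccnc2)cn1` in this assay gives > 100000 nM, again a limit of the assay. The difference between the core of compound 1 and the core of compound 3 is not broken down here. Compound 4 `CC(C)Oc1ncc(C(O)(c2cccnc2)c2ccc(Cl)cc2F)cn1` carries the same change relative to compound 3, namely (fluoro in place of hydrogen on an aromatic carbon). Because compound 3 already sits at the limit of > 100000 nM in this assay, at which 2 of the 3 values shown sit, the step from compound 3 to compound 4 is expected to be a step that the limit leaves unreadable from compound 3 to compound 4, and compound 4 is expected to give about 150000 nM in this assay, most likely again reported only as a limit.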

Compound 4, half-maximal inhibitory concentration: 89500 nM
Estimate against measurement, compound 4: 1.7-fold (0.22 log units) above; the range from low to high includes it.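

In this assay, fluoro in place of hydrogen on the core of compound 3 made a step of an at least 1.1-fold lower number from compound 3 to compound 4 (0.04 log units; that floor lies within the scatter). Set beside the same change on the core of compound 1, this step cannot be told apart from the earlier one: the same change on two cores in this assay, an at least 1.4-fold higher number (0.16 log units; that floor lies within the scatter) from compound 1 to compound 2 and an at least 1.1-fold lower number (0.04 log units; that floor lies within the scatter) from compound 3 to compound 4; the limit leaves it open whether they differ. Neither a shared size nor a real difference between the two cores is shown, and compound 2 and compound 3 each stand only at a limit of the assay: the limit of > 100000 nM in this assay, at which 2 of the 4 values shown sit.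

The compounds shown leave open how a methoxy group or a nitrile in place of that fluoro would read in this assay. They also leave open whether an amine on either core would give values clear of the limit.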